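Moving a Trifluoromethyl Group Around a Shared Core

This account rests on a few compounds, and the source may have more. Where it says the series, first, only, none or still open, it means among the compounds named here.

Three compounds built on one shared core were tested in a functional assay on LNCaP cells (Homo sapiens) for antiproliferative activity, read by propidium iodide staining, with a stated time of 96 h; a higher number here means a weaker inhibitor, a lower number a stronger inhibitor. Compound 1 `CC1(C)C(=O)N(c2ccc(S(F)(F)(F)(F)F)cc2)C(=S)N1c1ccc(C(F)(F)F)cc1` gives 47400 nM. Compound 2 `CC1(C)C(=O)N(c2ccc(S(F)(F)(F)(F)F)cc2)C(=S)N1c1cccc(C(F)(F)F)c1` differs from compound 1 in a single place: 3-(trifluoromethyl)phenyl in place of 4-(trifluoromethyl)phenyl on an amide-type nitrogen in a ring In this assay compound 2 gives 8800 nM, so that a 5.4-fold lower number from compound 1 to compound 2 (0.73 log units; beyond the scatter). Compound 3 `CC1(C)C(=O)N(c2cccc(S(F)(F)(F)(F)F)c2)C(=S)N1c1ccc(C(F)(F)F)cc1` also differs from compound 1, but the difference between the two cores is not broken down here. In this assay compound 3 gives 5200 nM, a number that lies within the scatter of compound 2 and well apart from compound 1.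

Compound 4 `CC1(C)C(=O)N(c2cccc(S(F)(F)(F)(F)F)c2)C(=S)N1c1cccc(C(F)(F)F)c1` has not been measured yet. Relative to compound 3 it carries the same change already seen between compound 1 and compound 2: 3-(trifluoromethyl)phenyl in place of 4-(trifluoromethyl)phenyl on an amide-type nitrogen in a ring The place of the change is described in identical words for both pairs, so the two changes are the same. Among the measured compounds shown here, the earlier instance produced a modest step, beyond the scatter, and it is the only instance available.

The step expected from compound 3 to compound 4 is estimated as a 2.6-fold lower number from compound 3 to compound 4 (0.41 log units; beyond the scatter), kept smaller than the earlier step because it rests on a single prior example a 5.4-fold lower number from compound 1 to compound 2 (0.73 log units; beyond the scatter) that started from the much weaker compound 1. In this assay compound 4 is therefore expected to give about 2000 nM, most likely between 700 nM and 6000 nM.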

Compound 4, half-maximal inhibitory concentration: 3400 nM
The estimate for compound 4 lay 1.7-fold (0.23 log units) below the measured number; measured number inside the range.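

In this assay, putting 3-(trifluoromethyl)phenyl in place of 4-(trifluoromethyl)phenyl on the second core gives a 1.5-fold lower number from compound 3 to compound 4 (0.18 log units; within the scatter), so on this core the change cannot be told apart from the ordinary spread of repeated measurements. The same change therefore did not carry over from one core to the other with the same size, and the gap between the two steps is larger than measurement scatter would explain: the same change on two cores in this assay, a 5.4-fold lower number (0.73 log units; beyond the scatter) from compound 1 to compound 2 and a 1.5-fold lower number (0.18 log units; within the scatter) from compound 3 to compound 4, 3.5-fold (0.55 log units) apart, beyond the scatter of two such steps This shows that, for these two pairs, the size of the step depends on the core that carries the change, so a step seen on one core is a poor guide to its size on the other; it does not show what in the cores causes the difference, and two pairs are too few to set a rule for the series.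

The compounds shown leave open how the same change would behave on any further core, which would help show whether the large step or the small one is more typical. They also leave open whether a different group in the place of trifluoromethyl on the same phenyl ring, such as a nitrile or a carboxylic acid, would depend on the core in the same way.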